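Swapping the aryl amide substituent on compound 3

A few compounds are considered here, and "the series" means these few. Any claim that something is new, unique, unknown or untested is made for them only; others in the source may bear on it.

In a functional assay on OVCAR-5 cells (Homo sapiens) for inhibition, read by CCK-8 assay, with a stated time of 72 h, tested at 10 uM (on this read-out lower numbers stand for less inhibition of growth and higher numbers for more inhibition of growth at the one concentration tested), compound 3 `CN(C)C(=O)c1cc2cnc(Nc3ccc(NC(=O)C4(C(=O)Nc5cccc(Cl)c5)CC4)cc3)nc2n1C1CCCC1` gives 88.1%, the highest of the three numbers, though its step of a number 0.3 percentage points higher from compound 1 to compound 3 (within the scatter) from compound 1 `CN(C)C(=O)c1cc2cnc(Nc3ccc(NC(=O)C4(C(=O)Nc5ccc(Br)cc5)CC4)cc3)nc2n1C1CCCC1` with 87.8% stays within the scatter. Compound 2 `CN(C)C(=O)c1cc2cnc(Nc3ccc(NC(=O)C4(C(=O)Nc5ccc(Cl)c(C(F)(F)F)c5)CC4)cc3)nc2n1C1CCCC1` gives 48%, and the step of a number 40.1 percentage points higher from compound 2 to compound 3 (beyond the scatter) is the only large one among the three.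

Compound 4 `Cc1ccc(NC(=O)C2(C(=O)Nc3ccc(Nc4ncc5cc(C(=O)N(C)C)n(C6CCCC6)c5n4)cc3)CC2)cc1` differs from compound 3 by 4-methylphenyl in place of 3-chlorophenyl on an amide-type nitrogen. Going by the values given here, two measured steps bear on this. The step of a number 0.3 percentage points higher from compound 1 to compound 3 (within the scatter) shows that exchanging one halogenated phenyl for another on this nitrogen leaves this assay unchanged, while a number 39.8 percentage points lower from compound 1 to compound 2 (beyond the scatter) shows that only the doubly substituted 4-chloro-3-(trifluoromethyl)phenyl lowers the number markedly. The 4-methylphenyl of compound 4 carries a single substituent, like 4-bromophenyl and 3-chlorophenyl, so a step within the scatter is expected, with a slight downward lean as the estimated a number 6.1 percentage points lower from compound 3 to compound 4 (within the scatter). Compound 4 is therefore expected to give 82% in this assay, within a range from 60% to 93%.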

Compound 4, percent growth inhibition at one concentration: 80.6%
For compound 4 the middle estimate is 1.4 percentage points above the measured one; the range from low to high includes it.
By their numbers in this assay, from the lowest: compound 2; then compounds 4, 1 and 3 (each within the scatter of the next).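

In this assay the methyl of compound 4 gives a number 7.5 percentage points lower from compound 3 to compound 4 (within the scatter) and also a number 7.2 percentage points lower from compound 1 to compound 4 (within the scatter) on this amide-type nitrogen, so among these compounds a single carbon substituent on the phenyl serves as well as a single halogen, and a halogen is not needed to keep the number in this range. Compound 2 alone goes against this pattern, and the new compound sets it apart again, with a number 32.6 percentage points higher from compound 2 to compound 4 (beyond the scatter) in the same assay. Nothing measured here gives a reason for either finding.

From the compounds shown here alone, whether an amine, a carboxylic acid or a methoxy group on this phenyl would stay with compound 1, compound 3 and compound 4 or fall towards compound 2 remains open. Also open, going by these compounds, is which group of compound 2 goes with its lower number, a question that a phenyl carrying trifluoromethyl alone would help to settle.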